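A few compounds are considered here, and "the series" means these few. Any claim that something is new, unique, unknown or untested is made for them only; others in the source may bear on it.

Measured compounds: compound 1 `O=C(Nc1cccc(-n2cc(-c3ccncc3)c(-c3cc(O)cc(Cl)c3)n2)c1)Nc1ccc(Cl)c(C(F)(F)F)c1` gives 2080 nM in a functional assay on UACC-62 cells (Homo sapiens) for inhibition, read by sulforhodamine B assay, with a stated time of 48 h; on this read-out higher numbers stand for weaker inhibition and lower numbers for stronger inhibition; compound 2 `COc1cc(Cl)cc(-c2nn(-c3cccc(NC(=O)Nc4ccc(Cl)c(C(F)(F)F)c4)c3)cc2-c2ccncc2)c1` gives 1270 nM in this assay; compound 3 `COc1cc(Cl)cc(-c2nn(-c3cccc(NC(=O)Nc4cccc(C(F)(F)F)c4)c3)cc2-c2ccncc2)c1` gives 1470 nM in this assay.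

Compound 2 carries the lowest number of the three, yet a 1.6-fold lower number from compound 1 to compound 2 (0.21 log units; within the scatter) and a 1.2-fold higher number from compound 2 to compound 3 (0.06 log units; within the scatter) both lie within the scatter, so no order among the three can be claimed.

Compound 4 `COc1cc(Cl)cc(-c2nn(-c3cccc(NC(=O)c4cccc(C(F)(F)F)c4)c3)cc2-c2ccncc2)c1` differs from compound 2 by 3-(trifluoromethyl)phenyl in place of (4-chloro-3-(trifluoromethyl)phenyl)amino on a carbonyl carbon. Neither measured step covers this change: a 1.2-fold higher number from compound 2 to compound 3 (0.06 log units; within the scatter) only removes a chloro from that ring and stays within the scatter, and a 1.6-fold lower number from compound 1 to compound 2 (0.21 log units; within the scatter) concerns a different ring. Nothing measured shows how this assay answers the loss of one hydrogen-bond donor together with the chloro, so the expectation is uncertain. Compound 4 is expected to give 2600 nM (range 900 nM to 7500 nM) in this assay. This amounts to an expected step of a 2.0-fold higher number from compound 2 to compound 4 (0.31 log units; beyond the scatter), a modest rise in the number that may well remain within the scatter.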

Compound 4, half-maximal inhibitory concentration: 8040 nM
For compound 4 the middle estimate is 3.1-fold (0.49 log units) below the measured one; measured number above the stated range.
By their numbers in this assay, from the lowest: compounds 2, 3 and 1 (each within the scatter of the next); then compound 4.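

In this assay, the change on the carbonyl carbon gives a 5.5-fold higher number from compound 3 to compound 4 (0.74 log units; beyond the scatter) and a 6.3-fold higher number from compound 2 to compound 4 (0.80 log units; beyond the scatter), so this place responds beyond the scatter, as neither earlier step did. In the first of these steps the 3-(trifluoromethyl)phenyl stays and only the amino nitrogen, with its hydrogen-bond donor, goes, so the rise follows the loss of that nitrogen alone. Nothing available explains this rise.

Going by these compounds, it remains open whether a methylamino group on the carbonyl carbon would keep the number near that of compound 3. Also open, on these data alone, is whether a chloro on the ring matters once the amino nitrogen is gone.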